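Cytotoxicity series: chloro in place of methoxy

The source may hold more compounds than are shown below. What is called first, only, known or untested is meant among the compounds shown, and "the series" means these compounds.

Compound 1, `COc1ccc(CNc2ccnc(N3CCN(C)CC3)n2)cc1`, in a functional assay on HepG2 cells (Homo sapiens) for cytotoxicity, read by MTT assay, with a stated time of 48 h (on this read-out higher numbers stand for weaker inhibition and lower numbers for stronger inhibition), gives > 200000 nM.
Compound 2, `COc1cccc(Nc2ccnc(N3CCN(C)CC3)n2)c1`, in this assay gives > 200000 nM.
Compound 3, `COc1ccc(Nc2nccc(N3CCN(C)CC3)n2)cc1`, in this assay gives > 200000 nM.

Each of these three values is a limit of the assay and not a number. Compound 3 therefore stands at the limit of > 200000 nM in this assay, at which 3 of the 3 values shown sit, and on this read-out nothing separates it from compound 1 or compound 2; all three sit at the same limit, so no ordering among them can be drawn.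

The next compound is compound 4, `CN1CCN(c2ccnc(Nc3ccc(Cl)cc3)n2)CC1`. It differs from compound 3 by chloro in place of methoxy on an aromatic carbon, with the rest of the shared core unchanged. Among the compounds with values here, no pair of measured compounds that differ in one place is available, so no measured step size guides the expectation; the only anchor is compound 3 sitting at the limit of > 200000 nM in this assay, at which 3 of the 3 values shown sit.

With that anchor, the step that the limit leaves unreadable from compound 3 to compound 4 is expected to be none beyond the scatter, in no clear direction. Compound 4 is accordingly estimated at 250000 nM, within a range from 80000 nM to 1000000 nM, and the most likely outcome is that the assay again reports only a limit rather than a number.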

Compound 4, half-maximal inhibitory concentration: > 200000 nM
Compound 4 gave a limit, no number; the forecaster's own chance of this, stated with the estimate: 80%; the middle value is on the limit's open side.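

Compound 4 gives > 200000 nM in this assay, which is a limit and not a number. No step from compound 3 to compound 4 can be read, because every value shown is a limit: the limit of > 200000 nM in this assay, at which 4 of the 4 values shown sit.

The compounds shown leave open whether any change to the shared core gives a measurable value in this assay, and how chloro and methoxy would then compare.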